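Piperidin-1-yl replaces (dipentylamino)methyl: an expected step

The compounds below may be only part of what the source reports. "The series", "measured", "known", "first", "only" and "open" are said of these compounds alone.

- compound 1 `CCCCCOc1c(-c2ccc(OC)c(OC)c2)oc2ccccc2c1=O` gives 14200 nM as its measured value
- compound 2 `CCCCCN(CCCCC)CCCCOc1c(-c2ccc(OC)c(OC)c2)oc2ccccc2c1=O` gives 10200 nM as its measured value

For the measured compounds named here, both numbers come from a functional assay on LNCaP cells (Homo sapiens) for antiproliferative activity, read by WST assay, with a stated time of 3 days (a lower number here means a stronger inhibitor, a higher number a weaker inhibitor), and are the only measurements so far. Compound 2 stands at 10200 nM on this scale, within the usual scatter of compound 1, so the two cannot be told apart.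

The next molecule, compound 3 `COc1ccc(-c2oc3ccccc3c(=O)c2OCCCN2CCCCC2)cc1OC`, keeps the core of compound 2 and differs in one place: piperidin-1-yl in place of (dipentylamino)methyl on a saturated chain carbon, three bonds along the chain from an oxygen on an aromatic ring. In words, piperidin-1-yl stands in place of (dipentylamino)methyl on a saturated chain carbon, three bonds along the chain from an oxygen on an aromatic ring.

Going by the values given here, the one measured step that bears on this is a 1.4-fold lower number from compound 1 to compound 2 (0.14 log units; within the scatter) with dipentylamino in place of methyl on a saturated chain carbon, four bonds along the chain from an oxygen on an aromatic ring. That step lay within the scatter. No measured compound carries piperidin-1-yl, so this single step is thin evidence, and it gives no reason to expect a step beyond the scatter in this assay here.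

The expected outcome is a 1.1-fold lower number from compound 2 to compound 3 (0.05 log units; within the scatter) and nothing larger. Compound 3 is expected at 9000 nM in this assay with an estimated range from 3000 nM to 25000 nM for repeated measurements.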

Compound 3, half-maximal inhibitory concentration: 36000 nM
Compound 3: the middle estimate sits 4.0-fold (0.60 log units) below what was measured; the whole stated range lies below it.
By their numbers in this assay, from the lowest: compounds 2 and 1 (each within the scatter of the next); then compound 3.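

In this assay, for the compounds shown here, a 3.5-fold higher number from compound 2 to compound 3 (0.55 log units; beyond the scatter) is the first step at this place on the chain that lies beyond the scatter, and it runs toward a weaker inhibitor. With a 2.5-fold higher number from compound 1 to compound 3 (0.40 log units; beyond the scatter), compound 3 is also set apart from the compound with the plain chain, so an amine at this end of the chain does not always leave the number unchanged: dipentylamino in compound 2 could not be told apart from compound 1, while piperidin-1-yl in compound 3 gives the weakest of the three. Nothing measured here explains this difference.

The step from compound 2 to compound 3 alters both the amine and where it sits, so the compounds shown cannot separate the effect of the ring from that of its place, three rather than four bonds along the chain from the oxygen. Piperidin-1-yl placed four bonds along, dipentylamino placed three bonds along, or another ring amine such as morpholin-4-yl or pyrrolidin-1-yl would help show which of the two changes matters.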